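Replacing the oxadiazole of compound 2 with a methylpiperazine

The compounds below may be only part of what the source reports. "The series", "measured", "known", "first", "only" and "open" are said of these compounds alone.

Compound 1, `Cc1cc(C)c(NC(=O)N(Cc2ccc(-c3n[nH]c(C)n3)cc2)C2CCCCCC2)c(C)c1`: in a functional assay on a cell-free system (plasma) with sterol O-acyltransferase, Soat (Rattus norvegicus) as the target (on this read-out higher numbers stand for an effect only at larger amounts of compound and lower numbers for an effect already at smaller amounts), compound 1 gives > 1 mg/kg, a limit of the assay.
Compound 2, `Cc1cc(C)c(NC(=O)N(Cc2ccc(-c3nnc(C)o3)cc2)C2CCCCCC2)c(C)c1`: in this assay compound 2 gives > 0.32 mg/kg, again only a limit.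
Compound 3, `Cc1cc(C)c(NC(=O)N(Cc2cccc(-c3nnnn3C)c2)C2CCCCCC2)c(C)c1`: in this assay compound 3 gives > 1 mg/kg, also a limit.

None of the three measured compounds has a numerical value in this assay; every value is a limit. Compound 2 sits at the limit of > 0.32 mg/kg in this assay, at which 1 of the 3 values shown sits, while compounds 1 and 3 sit at the limit of > 1 mg/kg in this assay, at which 2 of the 3 values shown sit. Among the compounds with values here, the one step between compounds differing in a single place, a step that the two limits leave unreadable from compound 1 to compound 2, is therefore of unreadable size, and no direction can be drawn from it.

Compound 4, `Cc1cc(C)c(NC(=O)N(Cc2ccc(N3CCN(C)CC3)cc2)C2CCCCCC2)c(C)c1`, is the unmeasured compound. It differs from compound 2 in one place: 4-methylpiperazin-1-yl in place of 5-methyl-1,3,4-oxadiazol-2-yl on an aromatic carbon. Within the data shown here, no measured step carries a comparable exchange, and the only step at hand is unreadable, so nothing in the data points toward a change in either direction beyond the scatter. Compound 4 is therefore expected to stay near compound 2, and the expected step that the limit leaves unreadable from compound 2 to compound 4 is close to nil. The estimate for compound 4 in this assay is 1 mg/kg, with a range from 0.3 mg/kg to 3 mg/kg, and a high chance that only a limit is reported.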

Compound 4, dose for half-maximal effect: > 1 mg/kg
Compound 4 ended at the assay's limit; the forecaster's own chance of this, stated with the estimate: 65%; the middle value lies on the limit itself.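

In this assay compound 4 gives > 1 mg/kg, again only a limit, so the steps to compound 4 from compound 1 and from compound 2 cannot be read. The compounds shown leave open where the actual values of compound 1, compound 2, compound 3 and compound 4 lie in this assay, and whether any of these exchanges changes the read-out at all.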